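The source may report more compounds than this note shows. Statements on the series, on what has been measured and on what is new or still open speak of the compounds shown alone.

Compound 1 `CC(C)Nc1nc(NCc2ccco2)c2ccccc2n1`: in a physicochemical assay for solubility, at pH 7.4 (a higher number here means a more soluble compound, a lower number a less soluble compound), compound 1 gives >= 30000 nM, a limit of the assay rather than a number.
Compound 2 `Cc1ccc2c(NCc3ccco3)nc(NC(C)C)nc2c1`: in this assay compound 2 gives <= 20000 nM, again only a limit.

Compound 2 therefore stands at a limit, with no exact number. Among the compounds with values here, the only measured step, an at least 1.5-fold lower number from compound 1 to compound 2 (0.17 log units; that floor lies within the scatter), rests on two limits and tells little. Compound 3 `COc1ccc2c(NCc3ccco3)nc(NC(C)C)nc2c1` differs from compound 2 by methoxy in place of methyl on an aromatic carbon. Within the data shown here, no measured step concerns this change, so compound 3 is expected to move no further than the scatter, a step that the limit leaves unreadable from compound 2 to compound 3. Compound 3 is estimated at 15000 nM, within a range from 5000 nM to 40000 nM.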

Compound 3, solubility: <= 20000 nM
Compound 3 was reported as a limit (the forecaster's own chance of this, stated with the estimate: 40%); the middle value does not contradict the limit.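

Methoxy in place of hydrogen on this aromatic carbon gives, in this assay, an at least 1.5-fold lower number from compound 1 to compound 3 (0.17 log units; that floor lies within the scatter). A second group at this position thus ends at the same limit that methyl reached. Compound 3 is also reported only as a limit and not a number, so the step between it and compound 2 cannot be read: the limit of <= 20000 nM in this assay, at which 2 of the 3 values shown sit.

Where compound 2 and compound 3 truly lie, and whether methoxy and methyl differ at all, stays open. Also open, from the compounds shown here alone, is how an amine or a carboxylic acid on this aromatic carbon would read in this assay.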